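Second chloro on the aryl amide of compound 3

The compounds below may be only part of what the source reports. "The series", "measured", "known", "first", "only" and "open" are said of these compounds alone.

Compound 3 `O=C(Nc1cccc(-c2nc3ccccc3s2)c1)c1cccnc1Cl` is known in an ADME assay on HEK293 cells (Homo sapiens) for inhibition, with a stated time of 72 h (on this read-out lower numbers stand for an effect already at smaller amounts and higher numbers for an effect only at larger amounts of compound), only as a limit: compound 3 gives > 25000 nM, which is a limit of the assay and not a number. Compound 1 `CC(Cl)C(=O)Nc1cccc(-c2nc3ccccc3s2)c1` gives > 25000 nM in this assay, also a limit. Compound 2 `O=C(Nc1cccc(-c2nc3ccccc3s2)c1)c1cnccc1Cl` gives > 25000 nM in this assay, again a limit. All three values sit at the limit of > 25000 nM in this assay, at which 3 of the 3 values shown sit, so the steps a step that the two limits leave unreadable from compound 1 to compound 2, a step that the two limits leave unreadable from compound 1 to compound 3 and a step that the two limits leave unreadable from compound 2 to compound 3 cannot be read in size or direction.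

Compound 4 `O=C(Nc1cccc(-c2nc3ccccc3s2)c1)c1ccc(Cl)nc1Cl` differs from compound 3 by chloro in place of hydrogen on an aromatic carbon. Cut one bond further out, the change reads 2-chloropyridin-3-yl to 2,6-dichloropyridin-3-yl on the carbonyl carbon. For the measured compounds named here, no measured step covers a chloro added in this way, and the three steps among compounds 1, 2 and 3 give no size because every value sits at the limit of > 25000 nM in this assay, at which 3 of the 3 values shown sit.

With all measured values at a limit, compound 4 is expected to stay at or near that limit in this assay, and the estimated step that the limit leaves unreadable from compound 3 to compound 4 is not expected to exceed the scatter. Compound 4 is therefore estimated at 30000 nM, with a range from 10000 nM to 100000 nM.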

Compound 4, half-maximal effective concentration: > 25000 nM
Compound 4: only a limit was reported (the forecaster's own chance of this, stated with the estimate: 85%); the middle value does not contradict the limit.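

No step among compound 1, compound 2, compound 3 and compound 4 can be read in size or direction, because each value is a limit and not a number: the limit of > 25000 nM in this assay, at which 4 of the 4 values shown sit.

The compounds shown leave open whether any group on the carbonyl carbon of the shared core gives a readable value in this assay.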